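A smaller group on the shared core

The compounds below may be only part of what the source reports. "The series", "measured", "known", "first", "only" and "open" are said of these compounds alone.

Three compounds built on one shared core have numbers in a functional assay on A549 cells (Homo sapiens) for antiproliferative activity, read by MTT assay, with a stated time of 48 h (on this read-out higher numbers stand for weaker inhibition and lower numbers for stronger inhibition), so far. Compound 1 (`CC(C)=CCC[C@]1(C)/C=C/[C@@H](OC(=O)C=C(C)C)[C@](C)(O)/C=C/C(=O)/C(CN(C(C)C)C(C)C)=C\C1`) carries diisopropylamino and gives 650 nM in this read-out. Compound 2 (`CC(C)=CCC[C@]1(C)/C=C/[C@@H](OC(=O)C=C(C)C)[C@](C)(O)/C=C/C(=O)/C(CN2CCN(C)CC2)=C\C1`) carries 4-methylpiperazin-1-yl and gives 940 nM in the same test. Compound 3 (`CC(C)=CCC[C@]1(C)/C=C/[C@@H](OC(=O)C=C(C)C)[C@](C)(O)/C=C/C(=O)/C(COC(=O)c2ccc([N+](=O)[O-])cc2)=C\C1`) carries ((4-nitrophenyl)carbonyl)oxy and gives 1310 nM which places it within the scatter of both others. The change to compound 4 (`CSC(=S)OC/C1=C/C[C@](C)(CCC=C(C)C)/C=C/[C@@H](OC(=O)C=C(C)C)[C@](C)(O)/C=C/C1=O`) is a group of 4 heavy atoms (2 carbon, 2 sulfur; no ring) in place of a group of 11 heavy atoms (7 carbon, 1 nitrogen, 3 oxygen; one six-membered aromatic ring of carbon only), on an oxygen on a saturated carbon and nothing else differs. The measured steps all exchange the group at one place on the core, and they are a 1.4-fold higher number from compound 1 to compound 2 (0.16 log units; within the scatter) and a 1.4-fold higher number from compound 2 to compound 3 (0.14 log units; within the scatter) and a 2.0-fold higher number from compound 1 to compound 3 (0.30 log units; within the scatter) with none of them beyond the scatter. Going by the values given here, no measured compound carries the entering group, so these steps bear on the change only indirectly. Given that compound 3 stands at 1310 nM and that these three different groups gave such small steps, no step beyond the scatter is expected in this assay for this exchange. The estimated step is a 1.3-fold lower number from compound 3 to compound 4 (0.12 log units; within the scatter) and no firm direction is expected for it. Compound 4 is estimated at 1000 nM with an expected range from 400 nM to 2500 nM in this test.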

Compound 4, half-maximal inhibitory concentration: 380 nM
Beside the measured number, compound 4's estimate is 2.6-fold (0.42 log units) above it; the measured number lies below the stated range.
By their numbers in this assay, from the lowest: compounds 4, 1, 2 and 3 (each within the scatter of the next, the first and the last beyond it).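

In this assay, going by these compounds alone, this exchange on an oxygen on a saturated carbon gives the first steps at this position that lie beyond the scatter: a 3.4-fold lower number from compound 3 to compound 4 (0.54 log units; beyond the scatter), and, with the whole group on the saturated chain carbon compared, a 2.5-fold lower number from compound 2 to compound 4 (0.39 log units; beyond the scatter). The earlier compounds, with three different groups, had shown only steps within the scatter, so the position is not indifferent to what it carries, although the steps remain modest. The comparison with the diisopropylamino group of compound 1 gives only a 1.7-fold lower number from compound 1 to compound 4 (0.23 log units; within the scatter), which lies within the scatter, so the group of 2 carbon and 2 sulfur atoms separates compound 4 from compound 2 and compound 3 but not from compound 1, and nothing given here explains this result.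

The compounds shown leave open whether the sulfur atoms matter at all, since no compound carries an acetyl group or a plain hydrogen on that oxygen. They also leave open how a longer chain in the entering group, or a primary amine on the saturated chain carbon, would stand in this assay.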